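The source may report more compounds than this note shows. Statements on the series, on what has been measured and on what is new or still open speak of the compounds shown alone.

In a functional assay on MCF7 cells (Homo sapiens) for cytotoxicity (on this read-out higher numbers stand for weaker inhibition and lower numbers for stronger inhibition), compound 1 (`C=C/C=C\[C@H](C)[C@H](OC(N)=O)[C@@H](C)[C@H](O)[C@@H](C)C/C(C)=C\[C@H](C)[C@@H](O)[C@@H](C)/C=C\CCc1cccc(F)c1`) gives 500 nM and compound 2 (`C=C/C=C\[C@H](C)[C@H](OC(N)=O)[C@@H](C)[C@H](O)[C@@H](C)C/C(C)=C\[C@H](C)[C@@H](O)[C@@H](C)/C=C\CCc1ccc(C)c(O)c1`) gives 4000 nM as the higher of the two numbers, so compound 2 is the weaker inhibitor of this pair. Compound 3 (`C=C/C=C\[C@H](C)[C@H](OC(N)=O)[C@@H](C)[C@H](O)[C@@H](C)C/C(C)=C\[C@H](C)[C@@H](O)[C@@H](C)/C=C\CCc1cccc(Cl)c1`) differs from compound 2 by one swap (3-chlorophenyl in place of 3-hydroxy-4-methylphenyl on a saturated chain carbon, two bonds along the chain from a double-bonded chain carbon) with 3-chlorophenyl in place of 3-hydroxy-4-methylphenyl on a saturated chain carbon, two bonds along the chain from a double-bonded chain carbon. Among the compounds with values here, one measured step bears on it: an 8.0-fold higher number from compound 1 to compound 2 (0.90 log units; beyond the scatter) came with 3-hydroxy-4-methylphenyl in place of 3-fluorophenyl. Within the data shown here, the new swap runs the other way, and 3-chlorophenyl is the closer match to the 3-fluorophenyl of compound 1, though no chlorine-bearing compound has been measured yet. Expected, then, is an 8.0-fold lower number from compound 2 to compound 3 (0.90 log units; beyond the scatter) in this assay as a move toward stronger inhibition of similar size to that one step. For compound 3 the estimate is 500 nM with 200 nM to 1300 nM as the expected range.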

Compound 3, half-maximal inhibitory concentration: 650 nM
The estimate for compound 3 lay 1.3-fold (0.11 log units) below the measured number; low and high end bracket the measured number.
By their numbers in this assay, from the lowest: compounds 1 and 3 (each within the scatter of the next); then compound 2.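

In this assay, the swap to 3-chlorophenyl brings a 6.2-fold lower number from compound 2 to compound 3 (0.79 log units; beyond the scatter), so two different halogen-bearing rings now stand apart from the 3-hydroxy-4-methylphenyl ring of compound 2, not just one. Chloro in place of fluoro on the aromatic carbon gives a 1.3-fold higher number from compound 1 to compound 3 (0.11 log units; within the scatter), so this read-out does not separate these two halogens on this ring. No evidence is available here on what lies behind these numbers.

The 3-hydroxy-4-methylphenyl group differs from both halogen-bearing rings in carrying a hydroxy and a methyl together, and the compounds shown cannot say which of the two goes with the higher number of compound 2. Also open, going by these compounds, is how a ring carrying an amine or a methoxy group, or a longer chain leading to the ring, would read.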